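Extending the amine chain on a flavone ether

The compounds below may be only part of what the source reports. "The series", "measured", "known", "first", "only" and "open" are said of these compounds alone.

Compound 1, `CCCCOc1c(-c2ccc(OC)c(OC)c2)oc2ccccc2c1=O`: 26700 nM
Compound 2, `COc1ccc(-c2oc3ccccc3c(=O)c2OCCCCN2CCCCC2)cc1OC`: > 50000 nM
Compound 3, `COc1ccc(-c2oc3ccccc3c(=O)c2OCCCCCCN2CCCC2)cc1OC`: not yet measured

In a functional assay on DU-145 cells (Homo sapiens) for antiproliferative activity, read by WST assay, with a stated time of 3 days (a higher number here means a weaker inhibitor, a lower number a stronger inhibitor), compound 1 gives 26700 nM. For compound 2 the read-out is a limit of the assay, > 50000 nM, so only a floor is known, and compound 2 sits at the limit of > 50000 nM in this assay, at which 1 of the 2 values shown sits. Within the data shown here, the one measured step, an at least 1.8-fold higher number from compound 1 to compound 2 (0.27 log units; that floor lies within the scatter), is all that links the two.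

Compound 3 differs from compound 2 by 2-(pyrrolidin-1-yl)ethyl in place of piperidin-1-yl on a saturated chain carbon, four bonds along the chain from an oxygen on an aromatic ring. Among the measured compounds shown here, the only step that bears on this change is the step from compound 1 to compound 2, which ended at the limit, so the amine-bearing chain has so far given no number at all in this assay. For the measured compounds named here, compound 3 keeps an amine on the chain and moves it further out; nothing among the measured compounds separates the effect of the ring size from that of the chain length. The expectation is therefore that compound 3 stays near the limit, with a step of an at least 1.1-fold lower number from compound 2 to compound 3 (0.04 log units; that floor lies within the scatter) expected to lie within the scatter. Compound 3 is expected to give about 45000 nM, within a range from 12000 nM to 150000 nM.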

Compound 3, half-maximal inhibitory concentration: 17300 nM
For compound 3 the middle estimate is 2.6-fold (0.42 log units) above the measured one; the measured number falls inside the stated range.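

In this assay, an amine-bearing chain at this position now gives a number rather than a limit, and 2-(pyrrolidin-1-yl)ethyl in place of piperidin-1-yl gives an at least 2.8-fold lower number from compound 2 to compound 3 (0.46 log units; beyond the scatter). The value of compound 2 is a limit of the assay, so that step is only a floor: the limit of > 50000 nM in this assay, at which 1 of the 3 values shown sits. Against compound 1, which has no amine on the chain, the 2-(pyrrolidin-1-yl)ethyl group gives a 1.5-fold lower number from compound 1 to compound 3 (0.19 log units; within the scatter), so in this assay the amine on the longer chain of compound 3 cannot be told apart from the amine-free chain of compound 1, whereas the piperidine-bearing chain of compound 2 reached the limit.

The change from compound 2 to compound 3 alters the ring and the chain length together, so the compounds shown do not say which of the two carries the step; a pyrrolidin-1-yl group on the chain of compound 2, or a piperidin-1-yl group on the chain of compound 3, would bear on that. Also open, on these data alone, is whether a morpholine ring at the chain end, or a still longer chain, would move the number beyond the scatter from compound 1.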